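The source may hold more compounds than are shown below. What is called first, only, known or untested is meant among the compounds shown, and "the series" means these compounds.

Measured in a functional assay on COLO 205 cells (Homo sapiens) for cytotoxicity, read by MTT assay, with a stated time of 72 h; on this read-out higher numbers stand for weaker inhibition and lower numbers for stronger inhibition:
Compound 1, `COc1ccc(C(=O)c2cc(OC)c(OC)c(OC)c2)cc1N`: 200 nM
Compound 2, `COc1ccc(/C=C/C(=O)Nc2cc(C(=O)c3cc(OC)c(OC)c(OC)c3)ccc2OC)cc1`: 10900 nM

Of these two numbers, compound 2 has the higher one, and it stands a long way from compound 1 in the direction of weaker inhibition, a gap well beyond the usual scatter. Compound 3, `COc1ccc(C(=O)c2cc(OC)c(OC)c(OC)c2)cc1NC(=O)/C=C/c1ccc(C(F)(F)F)cc1`, keeps everything in compound 2 except one change: trifluoromethyl in place of methoxy on an aromatic carbon. Going by the values given here, no measured pair shows this same swap, so nothing here fixes the size of the step. In the absence of such a pair the expectation is a step that stays within the scatter, a 1.1-fold lower number from compound 2 to compound 3 (0.04 log units; within the scatter). Compound 3 is therefore estimated at 10000 nM, with a range from 3000 nM to 35000 nM.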

Compound 3, half-maximal inhibitory concentration: 2600 nM
Beside the measured number, compound 3's estimate is 3.8-fold (0.59 log units) above it; measured number outside the range, below it.
By their numbers in this assay, from the lowest: compound 1; then compound 3; then compound 2.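

In this assay, swapping 4-methoxyphenyl for 4-(trifluoromethyl)phenyl gives a 4.2-fold lower number from compound 2 to compound 3 (0.62 log units; beyond the scatter) and so points to stronger inhibition. Going by these compounds alone, the group at this position, para to a large group, therefore affects the read-out, which the earlier compounds could not show. Nothing available gives a reason for this step. As far as these compounds go, it remains open how a fluorine, an amine or a carboxylic acid would fare at this position. A single pair also cannot show whether the same swap would give a similar step on a different core.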